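This account rests on a few compounds, and the source may have more. Where it says the series, first, only, none or still open, it means among the compounds named here.

Solubility notes on the series. In a physicochemical assay for solubility, with a stated time of 18 h, at pH 7.4 (on this read-out lower numbers stand for lower solubility and higher numbers for higher solubility), compound 3 `COc1cccc(CNCCCNc2ccnc3cc(Cc4cccc(C(F)(F)F)c4)ccc23)c1O` gives 4200 nM, the lowest of the three numbers; compound 1 `COc1cccc(CNCCCNc2ccnc3cc(Oc4ccccc4)ccc23)c1O` gives 14500 nM and compound 2 `COc1ccccc1Oc1ccc2c(NCCCNCc3ccco3)ccnc2c1` gives 14500 nM in this assay. Within the data shown here, the one single-point step seen so far, a 3.5-fold lower number from compound 1 to compound 3 (0.54 log units; beyond the scatter), runs in the opposite sense to the change now considered. Compound 4 `COc1ccccc1Oc1ccc2c(NCCCNCc3cccc(OC)c3O)ccnc2c1` differs from compound 3 as 2-methoxyphenoxy in place of 3-(trifluoromethyl)benzyl on an aromatic carbon. Compound 2 already carries 2-methoxyphenoxy at that position, with a different chain end, and its value sits with compound 1. The step to compound 4 is therefore expected to reverse the earlier loss, roughly a 3.3-fold higher number from compound 3 to compound 4 (0.52 log units; beyond the scatter). Compound 4 is estimated at 14000 nM in this assay, within 6000 nM to 30000 nM.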

Compound 4, solubility: 14500 nM
Estimate against measurement, compound 4: 1.0-fold (0.02 log units) below, and the stated range covers the measured number.
By their numbers in this assay, from the lowest: compound 3; then compounds 1, 2 and 4 (each within the scatter of the next).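

With 2-methoxyphenoxy in place of 3-(trifluoromethyl)benzyl on the aromatic carbon, this assay shows a 3.5-fold higher number from compound 3 to compound 4 (0.54 log units; beyond the scatter), so the lower number of compound 3 does not carry over to this replacement. The other two changes show no change at the digits printed from compound 1 to compound 4 (within the scatter) and no change at the digits printed from compound 2 to compound 4 (within the scatter), so neither methoxy in place of hydrogen nor 2-hydroxy-3-methoxyphenyl in place of furan-2-yl separates these compounds. No supporting measurement bears on the origin of these results.

Going by these compounds, whether the lower number of compound 3 follows the trifluoromethyl group or the benzyl carbon remains open. An unsubstituted benzyl group at this position would separate the two.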